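The compounds below may be only part of what the source reports. "The series", "measured", "known", "first", "only" and "open" are said of these compounds alone.

Of the compounds shown here, two have so far been tested in a functional assay on the whole organism (plasma) with Rattus norvegicus as the target; on this read-out lower numbers stand for an effect already at smaller amounts and higher numbers for an effect only at larger amounts of compound. Compound 1 (`CSc1cc(C)nc(SC)c1NC(=O)N(Cc1ccc(N(C)C)cc1)Cc1cccc(-c2cc[nH]n2)c1`) gives < 0.1 mg/kg as a limit of the assay and not a number. Compound 1 thus stands at the limit of < 0.1 mg/kg in this assay, at which 1 of the 2 values shown sits, and has no exact figure. Compound 2 (`O=C(Nc1c(F)cc(F)cc1F)N(Cc1ccccc1)Cc1cccc(-c2cc[nH]n2)c1`) gives 0.096 mg/kg as a true number and supplies the only exact figure so far. Compound 3 (`COc1ccc(CN(Cc2cccc(-c3cc[nH]n3)c2)C(=O)Nc2c(SC)cc(C)nc2SC)cc1`) keeps the core of compound 1 and carries a single change (methoxy in place of dimethylamino on an aromatic carbon) in which methoxy takes the place of dimethylamino on an aromatic carbon, para to a large group. Put another way, 4-(dimethylamino)benzyl becomes 4-methoxybenzyl while the rest of the molecule stays as it was. For the measured compounds named here, no measured pair isolates this swap, so the expectation is a cautious one. It leans on compound 2 at 0.096 mg/kg as the one exact anchor available. The expected step that the limit leaves unreadable from compound 1 to compound 3 in this assay stays within the usual scatter and has no clear direction. In this assay compound 3 is estimated at 0.08 mg/kg within an expected range from 0.03 mg/kg to 0.25 mg/kg until its measurement arrives.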

Compound 3, dose for half-maximal effect: < 0.1 mg/kg
Compound 3: a limit, no number; the forecaster's own chance of this, stated with the estimate: 35%; the middle value lies beyond the limit too.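

No new step can be read from compound 1 to compound 3 in this assay, because each of the two compounds gives a limit and not a number: the limit of < 0.1 mg/kg in this assay, at which 2 of the 3 values shown sit.

The compounds shown leave open whether methoxy in place of dimethylamino shifts the dose for half-maximal effect at all, and in which direction.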